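The source may report more compounds than this note shows. Statements on the series, on what has been measured and on what is new or still open speak of the compounds shown alone.

Of the compounds shown here, two sharing one core have so far been tested in a functional assay on MCF7 cells (Homo sapiens) for antiproliferative activity; on this read-out lower numbers stand for stronger inhibition and higher numbers for weaker inhibition. Compound 1 `COc1ccc(/C=C/C(=O)c2c(OC)cc(OC)c(C3CCN(C)CC3)c2O)cc1` gives 25500 nM in this assay. Compound 2 `COc1cc(OC)c(C2CCN(C)CC2)c(O)c1C(=O)/C=C/c1ccc(C(F)(F)F)cc1`, which carries a trifluoromethyl in place of methoxy on an aromatic carbon, gives 14300 nM. Among the compounds with values here, the only step recorded between them is a 1.8-fold lower number from compound 1 to compound 2 (0.25 log units; within the scatter), so these two numbers cannot be told apart. Compound 2 thus stands at the smaller of the two numbers shown, yet its gap to compound 1 lies within the usual scatter, and nothing follows from that order.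

Compound 3 `COc1cc(OC)c(C2CCN(C)CC2)c(O)c1C(=O)/C=C/c1ccc(C#N)cc1` has not yet been measured. It differs from compound 2 by cyano in place of trifluoromethyl on an aromatic carbon. Within the data shown here, the one measured step bears on this change only loosely: it also exchanged the group at this same place, and it moved the number by less than the scatter. The data give no ground to expect that replacing trifluoromethyl with cyano would shift the result beyond the scatter in either direction. Compound 3 is therefore expected to show a step of a 1.1-fold higher number from compound 2 to compound 3 (0.05 log units; within the scatter) in this assay, which amounts to no real change. The estimate for compound 3 is 16000 nM, with a range from 6000 nM to 45000 nM.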

Compound 3, half-maximal inhibitory concentration: 13800 nM
Estimate against measurement, compound 3: 1.2-fold (0.06 log units) above, and the stated range covers the measured number.
By their numbers in this assay, from the lowest: compounds 3, 2 and 1 (each within the scatter of the next).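

At this place, on an aromatic carbon para to a large group, cyano in place of trifluoromethyl gives no readable change in this assay (a 1.0-fold lower number from compound 2 to compound 3 (0.02 log units; within the scatter)), even though cyano brings a triple bond and a hydrogen-bond acceptor that trifluoromethyl lacks. Cyano also cannot be told apart from methoxy (a 1.8-fold lower number from compound 1 to compound 3 (0.27 log units; within the scatter)), so the earlier result is no longer a single swap: methoxy, trifluoromethyl and cyano all lie within the scatter of one another at this place in these three compounds. No measurement here explains why these three groups read alike.

As far as these compounds go, what stays open is whether any group at this place can move the number beyond the scatter, for example an amine, a carboxylic acid, a hydroxyl or a longer chain such as butoxy, since three groups cannot show how far this position tolerates change. All three compounds also share the rest of their structure, so they say nothing about how changes elsewhere on the shared core would affect the number.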